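The source may report more compounds than this note shows. Statements on the series, on what has been measured and on what is new or still open speak of the compounds shown alone.

Measured in a functional assay on the whole organism with Rattus norvegicus as the target; a higher number here means that more compound is needed for the effect, a lower number that less compound is needed:
Compound 1 `CCOC(=O)C(=O)Nc1cccc(OC)c1C#N`: 5.3 mg/kg
Compound 2 `CCOC(=O)C(=O)Nc1ccc(N(C)C)cc1C#N`: 1 mg/kg
Compound 3 `CCOC(=O)C(=O)Nc1cc(N(C)C)ccc1C#N`: 1.9 mg/kg

Of these three, compound 1 has the highest number, and it stands beyond the scatter from both of the others. Compound 2 and compound 3 lie within the usual scatter of each other.

The next compound, compound 4 `CCOC(=O)C(=O)Nc1cccc(N(C)CC)c1C#N`, has not yet been measured. It departs from compound 1 at one place, on an aromatic carbon ortho to a cyano group, with ethyl(methyl)amino in place of methoxy on an aromatic carbon.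

Among the measured compounds shown here, no measured pair isolates this change, so the expectation rests on indirect evidence. Compound 2, at 1 mg/kg, and compound 3, at 1.9 mg/kg, carry a dimethylamino group and no methoxy, but their cores differ from that of compound 1 in more than this one group. A lower number is therefore expected, though only a modest drop, close to the edge of the scatter. The expected step is a 2.1-fold lower number from compound 1 to compound 4 (0.33 log units; beyond the scatter). The estimate for compound 4 is 2.5 mg/kg, with an expected range from 0.9 mg/kg to 7 mg/kg.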

Compound 4, dose for half-maximal effect: 0.3 mg/kg
Estimate against measurement, compound 4: 8.3-fold (0.92 log units) above; measured number outside the range, below it.
By their numbers in this assay, from the lowest: compound 4; then compounds 2 and 3 (each within the scatter of the next); then compound 1.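

In this assay, among the compounds shown here, ethyl(methyl)amino in place of methoxy on the aromatic carbon ortho to a cyano group gives an 18-fold lower number from compound 1 to compound 4 (1.25 log units; beyond the scatter), the only step here that isolates a single change. It shows that the number responds strongly to the group at this position, which compound 2 and compound 3 could not show, as each differs from compound 1 in more than one place. Nothing measured here bears on why the step is so large.

The compounds shown leave open whether the step belongs to the amine nitrogen or to the longer chain, a question that ethoxy or diethylamino on this same carbon would address. Going by these compounds, it also remains open whether a cyclic amine such as pyrrolidine at this position would give a similarly low number.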